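Fluoro in Place of Methoxy on the Phenyl Ring

A few compounds are considered here, and "the series" means these few. Any claim that something is new, unique, unknown or untested is made for them only; others in the source may bear on it.

Measured compounds:
Compound 1 `COc1ccc(-c2ccnc(Nc3ccc4c(c3)c(/C=C3/C(=O)Nc5ccccc53)cn4C)n2)cc1`: in a functional assay on PA-1 cells (Homo sapiens) for cytotoxicity, read by MTT assay, with a stated time of 48 h (on this read-out higher numbers stand for weaker inhibition and lower numbers for stronger inhibition), compound 1 gives > 100000 nM, a limit of the assay rather than a number.
Compound 2 `Cn1cc(/C=C2/C(=O)Nc3ccccc32)c2cc(Nc3nccc(-c4ccc(O)cc4)n3)ccc21`: in this assay compound 2 gives 9270 nM.

Going by the values given here, compound 1 stands at the top of what this assay reports, at the limit of the limit of > 100000 nM in this assay, at which 1 of the 2 values shown sits; the only measured step that leaves it is the one to compound 2, where hydrogen replaces methyl on an oxygen on an aromatic ring and the number falls by an at least 10-fold lower number from compound 1 to compound 2 (1.03 log units; beyond the scatter).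

Compound 3 `Cn1cc(/C=C2/C(=O)Nc3ccccc32)c2cc(Nc3nccc(-c4ccc(F)cc4)n3)ccc21` is the unmeasured compound. It differs from compound 1 by fluoro in place of methoxy on an aromatic carbon. Among the compounds with values here, no measured step covers this exact change; the step to compound 2 is the only one that touches the same 4-methoxyphenyl group, and it shows that altering that group can move the number far. On that slim basis, compound 3 is expected to leave the limit but only modestly, with an estimated step of an at least 2.0-fold lower number from compound 1 to compound 3 (0.30 log units; that floor lies within the scatter). The estimate for compound 3 is 50000 nM, within a range from 10000 nM to 200000 nM.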

Compound 3, half-maximal inhibitory concentration: 31800 nM
Estimate against measurement, compound 3: 1.6-fold (0.20 log units) above; the range from low to high includes it.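

Replacing methoxy with fluoro gives an at least 3.1-fold lower number from compound 1 to compound 3 (0.49 log units; beyond the scatter), so a second group, this one without the oxygen, also brings the number down from the top of the read-out. On these data alone, the true size of this step remains unknown, since compound 1 stands at a limit rather than at a number: the limit of > 100000 nM in this assay, at which 1 of the 3 values shown sits. The two replacements do not end at the same level, as fluoro in place of hydroxy gives a 3.4-fold higher number from compound 2 to compound 3 (0.54 log units; beyond the scatter); the group at this place therefore still matters once methoxy has gone, and the three compounds rank hydroxy ahead of fluoro, with methoxy last, with none going against that order.

Three groups on one aromatic carbon cannot show what sets this order, and the data offer no reason for it. As far as these compounds go, it remains open whether an amine, a chloro group or a carboxylic acid at this carbon would fall nearer to compound 2 or to compound 1, and whether hydroxy or fluoro would keep the same order elsewhere on the phenyl ring.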